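The source may report more compounds than this note shows. Statements on the series, on what has been measured and on what is new or still open speak of the compounds shown alone.

Measured in a functional assay on a cell-free system (Platelet, plasma, Homo sapiens) for inhibition; a higher number here means a weaker inhibitor, a lower number a stronger inhibitor:
- compound 1 `Cc1ccc(N(CCN2CCC(OCC(=O)O)CC2)C(=O)c2ccc(Cl)cc2)cc1`: 690 nM
- compound 2 `COc1cc(OC)cc(C(=O)N(CCN2CCC(OCC(=O)O)CC2)c2ccc(C)cc2)c1`: 530 nM

Not yet measured: compound 3 `COc1ccc(OC)c(C(=O)N(CCN2CCC(OCC(=O)O)CC2)c2ccc(C)cc2)c1`.

Compound 2 stands within the scatter of compound 1, so the two cannot be ordered on these numbers. The next change has 2,5-dimethoxyphenyl in place of 3,5-dimethoxyphenyl on a carbonyl carbon. Among the measured compounds shown here, only one measured step bears on it, also made on that carbonyl carbon: a 1.3-fold lower number from compound 1 to compound 2 (0.11 log units; within the scatter). That step stays small, but it is a single step and it involves a different group. For the measured compounds named here, no measured compound carries the 2,5-dimethoxyphenyl group, so the data give no direction, and no shift beyond the scatter is expected in this assay. The expected step is a 1.1-fold higher number from compound 2 to compound 3 (0.05 log units; within the scatter). For compound 3 the estimated value is 600 nM, with an expected range from 250 nM to 1400 nM.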

Compound 3, half-maximal inhibitory concentration: > 3000 nM
Compound 3: only a limit was reported (the forecaster's own chance of this, stated with the estimate: 3%); at least 5.0-fold (0.69 log units) between middle value and limit.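

In this assay, the 3,5-dimethoxyphenyl and 2,5-dimethoxyphenyl groups have the same atoms and counts, yet exchanging them on the carbonyl carbon gives an at least 5.6-fold higher number from compound 2 to compound 3 (0.75 log units; beyond the scatter); the earlier change at this place stayed small, with a 1.3-fold lower number from compound 1 to compound 2 (0.11 log units; within the scatter). The 2,5-dimethoxyphenyl group also compares poorly with 4-chlorophenyl, with an at least 4.3-fold higher number from compound 1 to compound 3 (0.63 log units; beyond the scatter), so this place tolerates some aryl groups but not every arrangement of the same methoxy groups. Compound 3 has only a limit, so the full size of both new steps remains unknown: the limit of > 3000 nM in this assay, at which 1 of the 3 values shown sits.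

The compounds shown do not tell whether the weakening follows from the 2,5-dimethoxyphenyl group as a whole or from one of its two methoxy groups. A phenyl group with a single methoxy on the same carbonyl carbon would bear on that question.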